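Amide substituent swap on the shared core: compound 3 outlook

The source may hold more compounds than are shown below. What is called first, only, known or untested is meant among the compounds shown, and "the series" means these compounds.

Going by the values given here, in an ADME assay for permeability, using PAMPA (on this read-out lower numbers stand for lower permeability and higher numbers for higher permeability), compound 2 `CC(C)(CCl)C(=O)Nc1cccc(-c2nc3ccccc3s2)c1` gives 891 10^-6 cm/s, the lower of the two numbers so far; compound 1 `C/C=C/C(=O)Nc1cccc(-c2nc3ccccc3s2)c1` gives 1640 10^-6 cm/s, and the two sit within the scatter of each other. Compound 3 `O=C(Nc1cccc(-c2nc3ccccc3s2)c1)c1ccnc(Cl)c1` carries 2-chloropyridin-4-yl in place of 1-(chloromethyl)-1-methylethyl on a carbonyl carbon. Among the compounds with values here, the one measured step, a 1.8-fold lower number from compound 1 to compound 2 (0.26 log units; within the scatter), concerns a different exchange on the same carbonyl carbon and gives no firm guide. No step beyond the scatter is therefore expected in this assay, with a 1.1-fold lower number from compound 2 to compound 3 (0.05 log units; within the scatter) as the estimated shift. Compound 3 is expected near 800 10^-6 cm/s, in the range 400 10^-6 cm/s to 1600 10^-6 cm/s.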

Compound 3, apparent permeability: 478 10^-6 cm/s
Estimate against measurement, compound 3: 1.7-fold (0.22 log units) above, within the range that was stated.
By their numbers in this assay, from the lowest: compounds 3, 2 and 1 (each within the scatter of the next, the first and the last beyond it).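

In this assay this place, the carbonyl carbon of the amide, now gives a step beyond the scatter, with 2-chloropyridin-4-yl in place of prop-1-en-1-yl (a 3.4-fold lower number from compound 1 to compound 3 (0.54 log units; beyond the scatter)). With 2-chloropyridin-4-yl in place of 1-(chloromethyl)-1-methylethyl the step stays within the scatter (a 1.9-fold lower number from compound 2 to compound 3 (0.27 log units; within the scatter)), so only compounds 1 and 3 separate. No measured evidence bears on the origin of either step.

Open, going by these compounds, is how a carboxylic acid or a primary amine on this carbonyl carbon would read. Also open, on these data alone, is how an unsubstituted phenyl ring would compare with 2-chloropyridin-4-yl.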